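The source may report more compounds than this note shows. Statements on the series, on what has been measured and on what is new or still open speak of the compounds shown alone.

Among the measured compounds shown here, in a functional assay on HT-29 cells (Homo sapiens) for inhibition, read by MTT assay, with a stated time of 3 days (on this read-out higher numbers stand for weaker inhibition and lower numbers for stronger inhibition), compound 1 `COc1ccc(COc2cc(/C=C\c3cc(OC)c(OC)c(OC)c3)ccc2OC)cc1` gives 47000 nM and compound 2 `COc1ccccc1/C=C/CCCOc1cc(/C=C\c2cc(OC)c(OC)c(OC)c2)ccc1OC` gives 86000 nM, which places compound 2 within the scatter of compound 1, the only other measured compound. Compound 3 `COc1cccc(/C=C/CCCOc2cc(/C=C\c3cc(OC)c(OC)c(OC)c3)ccc2OC)c1` carries 3-methoxyphenyl in place of 2-methoxyphenyl on a double-bonded chain carbon bound to a double-bonded chain carbon. For the measured compounds named here, the sole measured step, a 1.8-fold higher number from compound 1 to compound 2 (0.26 log units; within the scatter), bears on this change only indirectly, since it does not test the methoxy position. No step beyond the scatter is therefore expected in this assay. The estimated step is a 1.1-fold lower number from compound 2 to compound 3 (0.06 log units; within the scatter). For compound 3 the expected value is 75000 nM, with a range of 32000 nM to 170000 nM.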

Compound 3, half-maximal inhibitory concentration: 25000 nM
For compound 3 the middle estimate is 3.0-fold (0.48 log units) above the measured one, and the stated range ends above it.
By their numbers in this assay, from the lowest: compounds 3, 1 and 2 (each within the scatter of the next, the first and the last beyond it).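

In this assay, among the compounds shown here, 3-methoxyphenyl in place of 2-methoxyphenyl on a double-bonded chain carbon bound to a double-bonded chain carbon gives a modest change (a 3.4-fold lower number from compound 2 to compound 3 (0.54 log units; beyond the scatter)), so the position of the methoxy group on this ring matters, which the earlier compounds could not show. The 4-(3-methoxyphenyl)but-3-en-1-yl group and the 4-methoxyphenyl group on the saturated chain carbon still cannot be told apart (a 1.9-fold lower number from compound 1 to compound 3 (0.27 log units; within the scatter)). Nothing available explains the difference between the two methoxy positions.

Open, going by these compounds, is how 4-methoxyphenyl would behave at the end of this same chain. Also open, on these data alone, is whether a hydroxyl or an amine on this ring, or a shorter chain, would change the number further.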